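Working notes: expected tolerated concentration of compound 4

A few compounds are considered here, and "the series" means these few. Any claim that something is new, unique, unknown or untested is made for them only; others in the source may bear on it.

Measured so far in an ADME assay on Vero cells (Chlorocebus sabaeus) for cytotoxicity, read by MTT assay, with a stated time of 72 h; a higher number here means that more compound is tolerated, a lower number that less compound is tolerated:
compound 1 `Cc1ccccc1/C=N\NC(=S)N(Cc1ccccc1)Cc1ccccc1` gives 167000 nM
compound 2 `C=CCN(CC=C)C(=S)N/N=C\c1ccc(Cl)cc1` gives 213000 nM
compound 3 `C/C(=N/NC(=S)N(Cc1ccccc1)Cc1ccccc1)c1ccccc1` gives 167000 nM

Compound 3 stands level with compound 1, the two together being the lowest of the three numbers as written; compound 2 lies within the scatter of compound 3. Among the compounds with values here, the single measured step, no change at the digits printed from compound 1 to compound 3 (within the scatter), shows no change. Compound 4 `C/C(=N/NC(=S)N(Cc1ccccc1)Cc1ccccc1)c1ccc(F)cc1` differs from compound 3 by fluoro in place of hydrogen on an aromatic carbon; cut one bond further out, the change reads phenyl to 4-fluorophenyl. Within the data shown here, no measured step introduces a substituent on an aromatic ring, so nothing bears directly on this change. The step of a 1.0-fold higher number from compound 3 to compound 4 (0.01 log units; within the scatter) is therefore expected to stay within the scatter. Compound 4 is estimated at 170000 nM, ranging from 85000 nM to 340000 nM.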

Compound 4, half-maximal cytotoxic concentration: 160000 nM
Estimate against measurement, compound 4: 1.1-fold (0.03 log units) above; measured number inside the range.
By their numbers in this assay, from the lowest: compounds 4, 1, 3 and 2 (each within the scatter of the next).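

In this assay, within the data shown here, fluoro in place of hydrogen on an aromatic carbon, para to a large group, gives a 1.0-fold lower number from compound 3 to compound 4 (0.02 log units; within the scatter) and is the first measured step to place a substituent on that ring. At this position, the change from phenyl to 4-fluorophenyl therefore stays within the scatter. No supporting measurement bears on the reason for this result.

Still open, from the compounds shown here alone, is whether an amine, a carboxylic acid or a longer chain at the same position would also stay within the scatter. A single fluoro step cannot show how other groups would behave there.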